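Lipophilicity notes: compound 4 in the oxazolidinone series

This account rests on a few compounds, and the source may have more. Where it says the series, first, only, none or still open, it means among the compounds named here.

Measured so far:
compound 1 `O=C1CNC(=O)N1C[C@H]1CN(c2ccc(-n3cc(-c4ccccn4)cn3)c(F)c2)C(=O)O1` gives 1.25 in a physicochemical assay for lipophilicity, read by HPLC, measured as octanol-water partition; on this read-out higher numbers stand for higher lipophilicity and lower numbers for lower lipophilicity.
compound 2 `CC(=O)OC[C@H]1CN(c2ccc(-n3cc(-c4ccccn4)cn3)c(F)c2)C(=O)O1` gives 2.09 in this assay.
compound 3 `O=C1O[C@@H](CSc2cccs2)CN1c1ccc(-n2cc(-c3ccccn3)cn2)c(F)c1` gives 4.29 in this assay.

Compound 3 stands highest of the three numbers in this assay; the nearest is compound 2, which is a number 2.20 log units higher from compound 2 to compound 3 (beyond the scatter), and the furthest is compound 1, which is a number 3.04 log units higher from compound 1 to compound 3 (beyond the scatter). Compound 4 `CCC(=O)NC[C@H]1CN(c2ccc(-n3cc(-c4ccccn4)cn3)c(F)c2)C(=O)O1` differs from compound 3 by propanoylamino in place of (thiophen-2-yl)sulfanyl on a saturated chain carbon bound to a saturated ring carbon. Going by the values given here, no measured step carries a propanoylamino group, so the step of a number 2.20 log units higher from compound 2 to compound 3 (beyond the scatter) and the step of a number 3.04 log units higher from compound 1 to compound 3 (beyond the scatter) are the only guides: both show a large rise in this assay toward (thiophen-2-yl)sulfanyl at this place, with the smaller chain group of compound 2 landing between. A large downward step a number 2.49 log units lower from compound 3 to compound 4 (beyond the scatter) in this assay is therefore expected for compound 4. Compound 4 is estimated at 1.8, within a range from 1.3 to 2.4.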

Compound 4, partition coefficient: 2.2
Estimate against measurement, compound 4: 0.40 log units below, within the range that was stated.
By their numbers in this assay, from the lowest: compound 1; then compounds 2 and 4 (each within the scatter of the next); then compound 3.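

In this assay, propanoylamino and acetoxy on a saturated chain carbon bound to a saturated ring carbon cannot be told apart, a number 0.11 log units higher from compound 2 to compound 4 (within the scatter), so this change of chain group leaves the number within the scatter. The large gap to (thiophen-2-yl)sulfanyl persists, a number 2.09 log units lower from compound 3 to compound 4 (beyond the scatter), and 2,5-dioxoimidazolidin-1-yl remains lowest, a number 0.95 log units higher from compound 1 to compound 4 (beyond the scatter). No available evidence bears on these steps.

Going by these compounds, whether an amine, a carboxylic acid or a longer acyl chain at this place would stay with compound 2 and compound 4 or move toward compound 3 remains open.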